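This account rests on a few compounds, and the source may have more. Where it says the series, first, only, none or still open, it means among the compounds named here.

Measured so far in an ADME assay on microsomes from liver (Rattus norvegicus) for metabolic stability; a lower number here means that the compound disappears faster, a higher number that the compound lasts longer:
compound 1, `CCC(CC)(c1nnc[nH]1)c1ccc(-c2ccc3cc(F)cc(F)c3c2)[nH]c1=O`: 1.26 h
compound 2, `CCn1ncc2c(F)cc(-c3ccc(C(CC)(CC)c4nnc(C)[nH]4)c(=O)[nH]3)cc21`: see below
compound 3, `Cc1nc(C(c2ccc(-c3ccc4cccc(F)c4c3)[nH]c2=O)C(C)C)[nH]c1C`: 0.0733 h.

Compound 2 gives in this assay only a limit, > 3 h. the limit of > 3 h in this assay, at which 1 of the 3 values shown sits. Among the two numbers, compound 3 sits lowest, and the gap up to compound 1 lies beyond the usual scatter. Compound 4, `CC(C)NC(=O)CC(c1ccc(-c2ccc3cccc(F)c3c2)[nH]c1=O)C(C)C`, is not yet measured in this assay. It differs from compound 3 in one place: (isopropylcarbamoyl)methyl in place of 4,5-dimethyl-1H-imidazol-2-yl on a saturated chain carbon bound to an aromatic carbon and a saturated chain carbon. For the measured compounds named here, no measured pair in the set reports this kind of change, so no size of step can be read from the data. The expectation is a modest rise in this assay, with wide uncertainty: the step of a 2.7-fold higher number from compound 3 to compound 4 (0.44 log units; beyond the scatter) is estimated, giving compound 4 an expected 0.2 h, somewhere between 0.05 h and 0.8 h.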

Compound 4, half-life: < 0.0667 h
Compound 4 gave a limit, no number (the forecaster's own chance of this, stated with the estimate: 5%); middle value at least 2.9-fold (0.47 log units) away from the limit.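

In this assay compound 4 gives < 0.0667 h as a limit and not a number. On a saturated chain carbon bound to an aromatic carbon and a saturated chain carbon, (isopropylcarbamoyl)methyl in place of 4,5-dimethyl-1H-imidazol-2-yl gives an at least 1.0-fold lower number from compound 3 to compound 4 (0.04 log units; that floor lies within the scatter) as its step, so this change shows no gain in half-life at this place. The step gives only a floor, so the full size of the change cannot be read.

From the compounds shown here alone, whether a primary amine or a carboxylic acid at this place would last longer stays open. Also open, going by these compounds, is whether a smaller N-methyl amide would behave like (isopropylcarbamoyl)methyl.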